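The source may report more compounds than this note shows. Statements on the series, on what has been measured and on what is new or still open speak of the compounds shown alone.

In an in vitro ADME assay on microsomes from liver (Homo sapiens) for pharmacokinetics, read by LC-MS, with a stated time of 10 min, tested at 1 uM (on this read-out lower numbers stand for slow clearance and higher numbers for fast clearance), compound 1 (`CN1C[C@H](C(=O)Nc2ccccc2)[C@@H](c2ccc(/C=C/C(=O)Nc3ccccc3N)cc2)C1`) gives 7 mL/min/kg and compound 2 (`COc1ccc(NC(=O)[C@H]2CN(C)C[C@@H]2c2ccc(/C=C/C(=O)Nc3ccccc3N)cc2)cc1`) gives 14 mL/min/kg so the two values lie within the scatter of each other, and compound 2 cannot be separated from compound 1 on these numbers. The next compound is compound 3 (`CN1C[C@H](C(=O)Nc2ccc(C#N)cc2)[C@@H](c2ccc(/C=C/C(=O)Nc3ccccc3N)cc2)C1`). The change from compound 2 is cyano in place of methoxy on an aromatic carbon, para to a large group (cyano in place of methoxy on an aromatic carbon). Among the compounds with values here, no cyano compound has been measured. Within the data shown here, because a 2.0-fold higher number from compound 1 to compound 2 (0.30 log units; within the scatter) is the only measured step at that carbon, no step beyond the scatter is expected in this assay for this change. The estimated step is a 1.4-fold lower number from compound 2 to compound 3 (0.15 log units; within the scatter) and it remains an expectation. Compound 3 is estimated at 10 mL/min/kg (expected range 5 mL/min/kg to 20 mL/min/kg).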

Compound 3, clearance: 1 mL/min/kg
Compound 3: the middle estimate sits 10-fold (1.00 log units) above what was measured; measured number outside the range, below it.
By their numbers in this assay, from the lowest: compound 3; then compounds 1 and 2 (each within the scatter of the next).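

In this assay, the aromatic carbon para to a large group can move the read-out beyond the scatter: cyano in place of methoxy brings a 14-fold lower number from compound 2 to compound 3 (1.15 log units; beyond the scatter) and cyano in place of hydrogen brings a 7.0-fold lower number from compound 1 to compound 3 (0.85 log units; beyond the scatter) at this carbon. Within the data shown here, the only earlier step here, methoxy in place of hydrogen, stayed within the scatter, so that step gave no sign of how far this carbon could shift the number. Methoxy and cyano match in heavy atoms and hydrogen-bond acceptors as counted, so those counts do not separate compound 2 from compound 3, and no measurement bearing on the reason for the drop is available.

On these data alone, whether the slow clearance of compound 3 is particular to the nitrile remains open, as a trifluoromethyl or a carboxylic acid at the same carbon would be needed to tell. As far as these compounds go, whether cyano gives the same step on another carbon of this ring also remains open.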